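A few compounds are considered here, and "the series" means these few. Any claim that something is new, unique, unknown or untested is made for them only; others in the source may bear on it.

Three measured compounds share one core and differ at two places. Compound 1 `CNc1nc(NCC(C)(C)C)cc(-c2ccccn2)n1` gives 73 nM in a functional assay on HEK293 cells for agonist activity at G-protein coupled receptor 39 (Homo sapiens), read by inositol phosphate accumulation; a lower number here means that less compound is needed, a higher number that more compound is needed for the effect. Compound 2 `CNc1nc(NCc2ccc(Cl)cc2)cc(-c2ccccn2)n1` gives 15 nM, and compound 3 `Cc1nc(NCc2ccc(Cl)cc2)cc(-c2ccccn2)n1` gives 81 nM. Compound 2 thus has the lowest number of the three, and both of its neighbours lie beyond the scatter: a 4.9-fold lower number from compound 1 to compound 2 (0.69 log units; beyond the scatter) and a 5.4-fold higher number from compound 2 to compound 3 (0.73 log units; beyond the scatter).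

Compound 4 `CNc1nc(NCc2ccc(N(C)C(C)=O)cc2)cc(-c2ccccn2)n1` keeps the methylamino group of compound 2 and alters only the aromatic substituent: acetyl(methyl)amino in place of chloro on an aromatic carbon, on an aromatic carbon of a six-membered aromatic ring of carbon only, para to a large group. Neither measured step changes this position, so the two steps show only how much the numbers move when a single group is swapped on this core, modestly in either direction. Going by the values given here, for the swap of a chloro for an acetyl(methyl)amino no step is available, so the direction is open; a modest rise in the number is taken as the expectation, and compound 4 is estimated at 50 nM, between 12 nM and 200 nM, which would mean a 3.3-fold higher number from compound 2 to compound 4 (0.52 log units; beyond the scatter).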

Compound 4, half-maximal effective concentration: 1180 nM
For compound 4 the middle estimate is 24-fold (1.37 log units) below the measured one, outside the stated range (above it).
By their numbers in this assay, from the lowest: compound 2; then compounds 1 and 3 (each within the scatter of the next); then compound 4.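

On the aromatic carbon para to a large group, in this assay, replacing chloro with acetyl(methyl)amino gives a 79-fold higher number from compound 2 to compound 4 (1.90 log units; beyond the scatter). Going by these compounds alone, this is the first step classed as large, so this position on the shared core does not accept every group equally, and the change moves the number further than either the swap from tert-butyl to 4-chlorophenyl or the swap from methylamino to methyl. The change adds heavy atoms, a carbonyl double bond and a hydrogen-bond acceptor all at once, and no supporting measurement shows which of these features matters.

From the compounds shown here alone, a single swap cannot separate these features, so it remains open whether a small group such as fluoro or methoxy would keep the number close to that of compound 2. An acetylamino or a dimethylamino group at the same place would help show whether the rise follows the carbonyl, the methyl on the nitrogen or the whole group.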